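Amino alcohol series: trimming sec-butyl to isopropyl

The compounds below may be only part of what the source reports. "The series", "measured", "known", "first", "only" and "open" are said of these compounds alone.

Compound 3 `CCCCCCCCC[C@@H](O)[C@@H](N)[C@@H](C)CC` stands second highest of the three numbers in a functional assay on T47D cells (Homo sapiens) for antiproliferative activity, read by sulforhodamine B assay, with a stated time of 48 h (on this read-out higher numbers stand for weaker inhibition of growth and lower numbers for stronger inhibition of growth), giving 14000 nM; compound 2 `CCCCCCCCC[C@@H](O)[C@H](C)N` gives 12000 nM and compound 1 `CCCCCCCCCCCCCCC[C@@H](O)[C@@H](N)C(C)C` gives 18000 nM, both within the scatter of compound 3. Compound 4 `CCCCCCCCC[C@@H](O)[C@@H](N)C(C)C` differs from compound 3 by hydrogen in place of methyl on a saturated chain carbon, three bonds along the chain from an amine nitrogen. Among the measured compounds shown here, the only measured step that bears on this position is a 1.2-fold higher number from compound 2 to compound 3 (0.07 log units; within the scatter), and it stayed within the scatter. Compound 1 also carries an isopropyl, and its number sits close to that of compound 3, which again speaks for no shift. The step to compound 4 is therefore expected to stay within the scatter, no change at the digits printed from compound 3 to compound 4 (within the scatter). Compound 4 is estimated at 14000 nM, with a range from 7000 nM to 28000 nM.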

Compound 4, concentration for 50% growth inhibition: 17000 nM
Estimate against measurement, compound 4: 1.2-fold (0.08 log units) below; the measured number falls inside the stated range.
By their numbers in this assay, from the lowest: compounds 2, 3, 4 and 1 (each within the scatter of the next).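

In this assay, removing this methyl, sec-butyl to isopropyl, does not move the number beyond the scatter (a 1.2-fold higher number from compound 3 to compound 4 (0.08 log units; within the scatter)). With the chain held, isopropyl for methyl also stays within it (a 1.4-fold higher number from compound 2 to compound 4 (0.15 log units; within the scatter)). Hydrogen in place of hexyl does the same (a 1.1-fold lower number from compound 1 to compound 4 (0.02 log units; within the scatter)).

Going by these compounds, a phenyl or a carboxylic acid in place of the isopropyl remains open. Nothing available accounts for these flat numbers.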